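Replacing the 3-chloro-4-methoxyphenyl arm with 4-bromophenyl

The compounds below may be only part of what the source reports. "The series", "measured", "known", "first", "only" and "open" are said of these compounds alone.

Compound 1 `COc1ccc(-c2cncnc2-c2cc(OC)c(OC)c(OC)c2)cc1Cl` is the stronger of the two measured compounds. In a functional assay on HeLa cells (Homo sapiens) for antiproliferative activity, read by CCK-8 assay, with a stated time of 72 h (on this read-out higher numbers stand for weaker inhibition and lower numbers for stronger inhibition), compound 1 gives 320 nM, the lowest of the two numbers. The other measured compound, compound 2 `COc1cc(-c2ncncc2-c2ccc(OCC(F)(F)F)cc2)cc(OC)c1OC`, gives 10200 nM in this assay, a much higher number that lies beyond the usual scatter; it carries a differently substituted phenyl ring on the shared core, with no 3-chloro-4-methoxyphenyl present.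

Compound 3 `COc1cc(-c2ncncc2-c2ccc(Br)cc2)cc(OC)c1OC` is not yet measured. Relative to compound 1 it differs in one place: 4-bromophenyl in place of 3-chloro-4-methoxyphenyl on an aromatic carbon. The group enters on an aromatic carbon of a six-membered aromatic ring with 2 nitrogen, ortho to a large group, two atoms from the ring nitrogen.

Among the measured compounds shown here, with no measured step of this exact kind, the expectation for compound 3 rests on compound 1 at 320 nM and compound 2 at 10200 nM, whose phenyl arm also lacks the methoxy-bearing pattern of compound 1. Compound 3 is therefore expected to fall between them, and the step of a 4.7-fold higher number from compound 1 to compound 3 (0.67 log units; beyond the scatter) is estimated as a loss beyond the scatter. Compound 3 is estimated at 1500 nM in this assay, within a range of 400 nM to 6000 nM.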

Compound 3, half-maximal inhibitory concentration: 500 nM
Compound 3: middle estimate off by 3.0-fold (0.48 log units), on the high side, and the stated range covers the measured number.
By their numbers in this assay, from the lowest: compounds 1 and 3 (each within the scatter of the next); then compound 2.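

In this assay, the step of a 1.6-fold higher number from compound 1 to compound 3 (0.19 log units; within the scatter) lies within the scatter, so 3-chloro-4-methoxyphenyl and 4-bromophenyl cannot be told apart at this aromatic carbon of the shared core. The arm is not indifferent to every change, however: with bromo in place of 2,2,2-trifluoroethoxy, the step of a 20-fold lower number from compound 2 to compound 3 (1.31 log units; beyond the scatter) is large and lies beyond the scatter. No measurement shown accounts for either step.

Three compounds leave open how far the arm tolerates other groups, such as a plain methoxy, an ethoxy chain without fluorine, an amine or a carboxylic acid. A phenyl arm carrying chloro alone would also help separate the contributions of the chlorine and the methoxy in compound 1.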